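A Methyl Added to the Amino Acid Side Chain

The source may report more compounds than this note shows. Statements on the series, on what has been measured and on what is new or still open speak of the compounds shown alone.

Compound 2 `COc1cc(NC(C)CCCN2C(=O)CN(C(=O)[C@H](N)C(C)C)C2(C)C)c2ncccc2c1` is a ring-amide derivative of compound 1 `COc1cc(NC(C)CCCN2C(=O)CNC2(C)C)c2ncccc2c1`, carrying a (1-amino-2-methylpropyl)carbonyl group in place of hydrogen on an amine nitrogen in a ring. In an ADME assay on a cell-free system (plasma, Homo sapiens) for metabolic stability, with Plasma (Rattus norvegicus) as the target, read by HPLC (on this read-out lower numbers stand for a shorter-lived compound and higher numbers for a longer-lived compound), compound 1 reaches only a limit of the method, > 3 h. In this assay compound 2 likewise reaches only a limit, > 3 h. The step from compound 1 to compound 2 is therefore a step that the two limits leave unreadable from compound 1 to compound 2. Both values sit at the same limit (the limit of > 3 h in this assay, at which 2 of the 2 values shown sit), so compound 2 stands at the top of what the measurement can resolve.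

Compound 3 `CC[C@H](C)[C@@H](N)C(=O)N1CC(=O)N(CCCC(C)Nc2cc(OC)cc3cccnc23)C1(C)C` differs from compound 2 by methyl in place of hydrogen on a saturated chain carbon, three bonds along the chain from an amine nitrogen and a carbonyl carbon, which read one bond further out is isopropyl to sec-butyl. No measured step bears on this change; the only step shown is unreadable, and both measured compounds rest at the limit. Compound 3 is expected to change by a step that the limit leaves unreadable from compound 2 to compound 3, that is, to show no movement beyond the scatter. For compound 3 the estimated value in this assay is 5 h, with a range from 2 h to 12 h, most likely again reported only as a limit.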

Compound 3, half-life: > 3 h
Compound 3 ended at the assay's limit; the forecaster's own chance of this, stated with the estimate: 85%; the middle value does not contradict the limit.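

Compound 3, like compound 1 and compound 2, stands at a limit in this assay, so no step among these three compounds can be read: the limit of > 3 h in this assay, at which 3 of the 3 values shown sit.

The compounds shown leave open how long each one actually lasts past that limit, and whether methyl in place of hydrogen on the side chain changes it at all.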